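Fluorine in place of nitrile on the sulfonyl ring

The compounds below may be only part of what the source reports. "The series", "measured", "known", "first", "only" and "open" are said of these compounds alone.

Measured compounds:
Compound 1 `C=CCNC(=O)n1c(-c2ccc(OC)cc2)cc(=O)c2c(OC)cc(OC)cc21`: in a functional assay on KOPN-8 cells (Homo sapiens) for antiproliferative activity, with a stated time of 72 h (on this read-out lower numbers stand for an effect already at smaller amounts and higher numbers for an effect only at larger amounts of compound), compound 1 gives 12000 nM.
Compound 2 `COc1ccc(-c2cc(=O)c3c(OC)cc(OC)cc3n2S(=O)(=O)c2ccc([N+](=O)[O-])cc2)cc1`: in this assay compound 2 gives 17300 nM.
Compound 3 `COc1ccc(-c2cc(=O)c3c(OC)cc(OC)cc3n2S(=O)(=O)c2ccc(C#N)cc2)cc1`: in this assay compound 3 gives only a limit, > 17200 nM.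

Compound 3 therefore has no exact number here; its value is the limit of the assay, the point where one of the three values shown sits (the limit of > 17200 nM in this assay, at which 1 of the 3 values shown sits). Two measured steps lead to compound 3. The first, allylcarbamoyl to (4-cyanophenyl)sulfonyl on the ring nitrogen, reads an at least 1.4-fold higher number from compound 1 to compound 3 (0.15 log units; that floor lies within the scatter). The second, nitro to cyano on the sulfonyl ring, reads a step that the limit leaves unreadable from compound 2 to compound 3.

Compound 4 `COc1ccc(-c2cc(=O)c3c(OC)cc(OC)cc3n2S(=O)(=O)c2ccc(F)cc2)cc1` is the next step from compound 3: fluoro in place of cyano on an aromatic carbon. Neither measured step makes this same change, so they offer no direct guide. What the numbers do show is that compounds 1 and 2 both sit at the weak end of the scale, and compound 3 sits at the limit. On that basis compound 4 is expected to stay in the same weak region, with the expected step that the limit leaves unreadable from compound 3 to compound 4, meaning no change beyond the scatter. For compound 4 the estimate is 20000 nM, with a range from 8000 nM to 50000 nM, and a real chance that only a limit is reported again.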

Compound 4, half-maximal effective concentration: > 65500 nM
Compound 4: only a limit was reported; the forecaster's own chance of this, stated with the estimate: 60%; middle value at least 3.2-fold (0.51 log units) away from the limit.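

Within the data shown here, on the sulfonyl ring, at the carbon para to a large group, fluoro in place of nitro gives the only readable change at this position in this assay (an at least 3.7-fold higher number from compound 2 to compound 4 (0.57 log units; beyond the scatter)). This matters more than a single limit might suggest, since the exchange of the allylcarbamoyl on the ring nitrogen now also reads beyond the scatter with the (4-fluorophenyl)sulfonyl group (an at least 5.4-fold higher number from compound 1 to compound 4 (0.73 log units; beyond the scatter)), whereas the same exchange with the (4-cyanophenyl)sulfonyl group stayed within it (an at least 1.4-fold higher number from compound 1 to compound 3 (0.15 log units; that floor lies within the scatter)). Compound 4 still has no exact number, and its value is only a limit: the limit of > 65500 nM in this assay, at which 1 of the 4 values shown sits.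

Among these compounds, the step between compound 3 and compound 4 cannot be read, and neither can the one between compound 2 and compound 3, so the order of nitrile and fluoro on this ring stays open. Also open, on these data alone, is whether an amine or a carboxylic acid on this same carbon, or a sulfonyl ring with only hydrogen there, would move the result toward lower numbers.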